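Nitro to Amino on a Vinyl Sulfone Scaffold

A few compounds are considered here, and "the series" means these few. Any claim that something is new, unique, unknown or untested is made for them only; others in the source may bear on it.

Four compounds share a sulfone that links a benzyl group to a second aryl unit. Compound 1 `COc1cc(OC)c(/C=C/S(=O)(=O)Cc2ccc(OC)c(N)c2)c(OC)c1` carries an amino group and a trimethoxy-substituted vinyl partner; in a functional assay on T47D cells (Homo sapiens) for cytotoxicity, read by MTT assay, with a stated time of 72 h (on this read-out lower numbers stand for stronger inhibition of growth and higher numbers for weaker inhibition of growth), compound 1 gives "not determined" (no result reported). Compound 3 `COc1ccc(CS(=O)(=O)CC(=O)Nc2c(C)cc(C)cc2C)cc1N` replaces the vinyl partner with an amide. In this assay compound 3 reaches only a limit, > 30000 nM. Compound 2 `COc1ccc(CS(=O)(=O)/C=C/c2c(OC)cccc2OC)cc1[N+](=O)[O-]` carries a nitro group and a dimethoxy-substituted vinyl partner. In this assay compound 2 likewise sits at a limit, > 30000 nM, so it stands among the entries without a measured number, as noted by the limit of > 30000 nM in this assay, at which 2 of the 3 values shown sit.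

Compound 4 `COc1ccc(CS(=O)(=O)/C=C/c2c(OC)cccc2OC)cc1N` differs from compound 2 in one place: amino in place of nitro on an aromatic carbon. For the measured compounds named here, no measured pair shows such a swap on this core, and both measured neighbours give limits rather than numbers, so no step beyond the scatter is expected in either direction. For this assay compound 4 is expected at 30000 nM, within 8000 nM to 100000 nM. The expected change from compound 2 to compound 4 is a number no higher from compound 2 to compound 4 (the limit leaves the size open), essentially none.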

Compound 4, concentration for 50% growth inhibition: 50 nM
Compound 4: middle estimate off by 600-fold (2.78 log units), on the high side, and the stated range ends above it.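

On the shared core, amino in place of nitro on an aromatic carbon, ortho to a methoxy group, brings an at least 600-fold lower number from compound 2 to compound 4 (2.77 log units; beyond the scatter); in this assay, a lower number stands for stronger inhibition of growth. For the compounds shown here, the earlier compounds offered no measured pair that differed in one place, so this is the first sign that this single position can decide between a limit and a clear value. The true size of the step stays open because compound 2 stands at a limit of the assay, not at a number: the limit of > 30000 nM in this assay, at which 2 of the 4 values shown sit.

The compounds shown do not tell whether amino itself is needed, or whether a hydroxyl group or an acetamide on the same carbon would serve as well. In this assay, on these data alone, compound 1 gives "not determined" (no result reported), so it also remains open whether the amino result carries over to a trimethoxy-substituted vinyl partner.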